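The source may hold more compounds than are shown below. What is called first, only, known or untested is meant among the compounds shown, and "the series" means these compounds.

Compound 1 `Clc1ccc(Cn2cc(C3CC(c4ccncc4)=NO3)c3ccccc32)cc1` gives 25700 nM in a functional assay on PC-3 cells (Homo sapiens) for inhibition, read by MTT assay, with a stated time of 48 h; on this read-out lower numbers stand for stronger inhibition and higher numbers for weaker inhibition.
Compound 2 `COc1ccc2c(c1)c(C1CC(c3ccncc3)=NO1)cn2Cc1ccc(Cl)cc1` gives 55200 nM in this assay.
Compound 3 `Cc1c(C2CC(c3ccncc3)=NO2)c2ccccc2n1Cc1ccc(Cl)cc1` gives 11200 nM in this assay.

Among these three numbers, compound 1 stands second highest: its nearest neighbour is compound 2, reached by a 2.1-fold higher number from compound 1 to compound 2 (0.33 log units; beyond the scatter), and the furthest is compound 3, reached by a 2.3-fold lower number from compound 1 to compound 3 (0.36 log units; beyond the scatter). Both steps are modest, yet each lies beyond the usual scatter of repeated measurements.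

The unmeasured compound 4 `COc1ccc2c(C3CC(c4ccncc4)=NO3)cn(Cc3ccc(Cl)cc3)c2c1` differs from compound 1 in one place: methoxy in place of hydrogen on an aromatic carbon. It is therefore a second methoxy-bearing analogue of compound 1, but not the same compound as compound 2. Within the data shown here, the only measured step that bears on it is the one where a methoxy entered on an aromatic carbon, a 2.1-fold higher number from compound 1 to compound 2 (0.33 log units; beyond the scatter), which made the number modestly higher, that is, the inhibition weaker. Because that step was a 2.1-fold higher number from compound 1 to compound 2 (0.33 log units; beyond the scatter), compound 4 is expected to show a small shift in the same direction, a 1.4-fold higher number from compound 1 to compound 4 (0.13 log units; within the scatter), possibly no larger than the scatter. Compound 4 is thus estimated at 35000 nM, with a range from 15000 nM to 80000 nM.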

Compound 4, half-maximal inhibitory concentration: 95100 nM
The estimate for compound 4 lay 2.7-fold (0.43 log units) below the measured number; the measured number lies above the stated range.
By their numbers in this assay, from the lowest: compound 3; then compound 1; then compounds 2 and 4 (each within the scatter of the next).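

In this assay methoxy in place of hydrogen at this second place on the six-membered aromatic ring of carbon only again gives a higher number (a 3.7-fold higher number from compound 1 to compound 4 (0.57 log units; beyond the scatter)), so weaker inhibition with this change is now seen at two places on that ring, not one. Compounds 2 and 4 lie within the scatter of each other, so these numbers show no difference between the two methoxy places. Nothing available here explains why methoxy has this effect at either place.

Only hydrogen and methoxy are shown at this place, so it remains open how a hydroxyl, a chlorine or an amine would behave there. As far as these compounds go, whether a methyl here would lower the number, as the methyl at another place did in compound 3, also remains open.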